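The compounds below may be only part of what the source reports. "The series", "measured", "known", "first", "only" and "open" are said of these compounds alone.

In an assay on cells with melanin-concentrating hormone receptor 1 (Homo sapiens) as the target, read by radioligand binding (on this read-out higher numbers stand for weaker inhibition and lower numbers for stronger inhibition), compound 2 `CC(C)(C)CCOc1cccc2ccc(N)nc12` gives 201 nM, the only numerical value among the two results shown. Compound 1 `CC(C)OCCOc1cccc2ccc(N)nc12` reaches only the limit of this assay, > 2000 nM. Among the measured compounds shown here, the one measured step, an at least 9.9-fold lower number from compound 1 to compound 2 (0.99 log units; beyond the scatter), is the sole guide: it shows that exchanging an oxygen-bearing side chain for an all-carbon one moved the number down, and the evidence for compound 1 rests on the limit of > 2000 nM in this assay, at which 1 of the 2 values shown sits, rather than on a fixed value.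

Compound 3 `CCOCC(C)Oc1cccc2ccc(N)nc12` reverses the direction of that exchange. Relative to compound 2 it carries a group of 6 heavy atoms (5 carbon, 1 oxygen; no ring) in place of a group of 6 heavy atoms (6 carbon; no ring), on an oxygen on an aromatic ring, so the side chain again holds an oxygen, as the isopropoxy-bearing chain of compound 1 does, though arranged differently. Since the measured step from compound 1 to compound 2 was sizeable and ran toward lower numbers when the oxygen left the chain, the expectation for compound 3 is a step toward higher numbers, plausibly of comparable size, and possibly up to the limit of this assay. The estimate for compound 3 is therefore 1500 nM, within a range from 400 nM to 6000 nM, which corresponds to an expected step of a 7.5-fold higher number from compound 2 to compound 3 (0.87 log units; beyond the scatter).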

Compound 3, half-maximal inhibitory concentration: 1070 nM
Estimate against measurement, compound 3: 1.4-fold (0.15 log units) above, within the range that was stated.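

In this assay, among the compounds shown here, the step of a 5.3-fold higher number from compound 2 to compound 3 (0.73 log units; beyond the scatter) gives the first comparison in which both ends are numerical values rather than a limit. On an oxygen on an aromatic ring, with 6 heavy atoms on both sides of the exchange, the all-carbon 3,3-dimethylbutyl group therefore gives the lower number, and the group that holds an oxygen and a hydrogen-bond acceptor gives the higher one. The step of an at least 1.8-fold lower number from compound 1 to compound 3 (0.27 log units; that floor lies within the scatter) has a floor that does not set the two oxygen-bearing groups apart, so their order stays unresolved, and what is known about compound 1 is a limit rather than a number: the limit of > 2000 nM in this assay, at which 1 of the 3 values shown sits.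

The compounds shown leave open whether the higher number of compound 3 follows from the oxygen in the chain itself or from how the chain is arranged, since compound 2 differs from compound 3 in both respects. They also leave open how this place would respond to an amine in the chain, a longer all-carbon chain or a cyclohexyl group.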